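A few compounds are considered here, and "the series" means these few. Any claim that something is new, unique, unknown or untested is made for them only; others in the source may bear on it.

Series notes. Compound 1 `CCC(C(=O)N1CCN(c2cccc(C(F)(F)F)c2)CC1)N1C(=O)CCC1=O` carries a core that differs from that of compound 2 `CC(C(=O)N1CCOCC1)N1C(=O)CCC1=O` and compound 3 `CCC(C(=O)N1CCOCC1)N1C(=O)CCC1=O`; the difference between the two cores is not broken down here. In a functional assay on the whole organism (strain Swiss) with Mus musculus as the target, in the maximal electroshock model, with a stated time of 2 h, at a dose of 300 mg/kg by the intraperitoneal route (on this read-out lower numbers stand for a weaker effect and higher numbers for a stronger effect at the one dose given), compound 1 gives 50%. In this assay compound 2 gives 0% and compound 3 gives 0%. The change hydrogen in place of methyl on a saturated chain carbon, two bonds along the chain from an amide-type nitrogen in a ring and a carbonyl carbon made the step of no change at the digits printed from compound 3 to compound 2 (within the scatter). Compound 4 `CC(C(=O)N1CCN(c2cccc(C(F)(F)F)c2)CC1)N1C(=O)CCC1=O` is not yet measured; it arises from compound 1 by hydrogen in place of methyl on a saturated chain carbon, two bonds along the chain from an amide-type nitrogen in a ring and a carbonyl carbon, the same change. Within the data shown here, the one measured instance of this change, no change at the digits printed from compound 3 to compound 2 (within the scatter), was read from a value at the bottom of the scale and says little about what the change does from a value near the middle. For compound 4 the expected step is therefore small, a number 10 percentage points lower from compound 1 to compound 4 (within the scatter), and carries real uncertainty. The estimate for compound 4 is 40%, within a range from 10% to 70%.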

Compound 4, a percentage reported as activity, at one dose (the size of the read-out at that dose, not a potency): 100%
Estimate against measurement, compound 4: 60 percentage points below; the measured number lies above the stated range.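

In this assay, on the core carrying the trifluoromethyl group, ethyl to methyl gives a number 50 percentage points higher from compound 1 to compound 4 (beyond the scatter). The step therefore does not carry over at a fixed size from one core to the other: the same change on two cores in this assay, no change at the digits printed (within the scatter) from compound 3 to compound 2 and a number 50 percentage points higher (beyond the scatter) from compound 1 to compound 4, 50 percentage points apart, beyond the scatter of two such steps. Among these compounds, this does not show which part of the core sets the gap, and with only one pair per core, one of them starting from the bottom of the scale where compound 3 gives 0%, no general rule for the series follows.

The compounds shown leave open whether a propyl chain on the same saturated chain carbon would extend or reverse the step. They also leave open how the step behaves with a chlorine in place of the trifluoromethyl group.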